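Metabolic stability notes on a polyol azole series

This account rests on a few compounds, and the source may have more. Where it says the series, first, only, none or still open, it means among the compounds named here.

Measured so far:
compound 1 `CC(=O)c1ncc([C@@H](O)[C@H](O)[C@H](O)CO)s1` — 0.9 h
compound 2 `CCc1[nH]c(C(C)=O)nc1[C@@H](O)[C@H](O)[C@H](O)CO` — 2.8 h
compound 3 `CC(O)c1nc([C@@H](O)[C@H](O)[C@H](O)CO)c[nH]1` — 4.4 h

All three were run in an ADME assay on the whole organism (strain 129/SvEvBrd x C57BL/6) for metabolic stability, with Mus musculus as the target; on this read-out lower numbers stand for a shorter-lived compound and higher numbers for a longer-lived compound. Compound 3 holds the highest number of the three. Against compound 2 the gap is within the scatter, so the two cannot be ordered on this read-out. Against compound 1 the gap is beyond the scatter, and compound 3 is the longer-lived of that pair. Among the compounds with values here, no pair among the measured compounds differs in only one place, so no single structural step has yet been tied to a change in half-life.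

Compound 4 `OC[C@@H](O)[C@@H](O)[C@H](O)c1c[nH]c(-c2ncon2)n1` is the next compound for this assay. Relative to compound 3 it carries 1,2,4-oxadiazol-3-yl in place of 1-hydroxyethyl on an aromatic carbon. The group that leaves carries a hydroxyl; the group that enters is a five-membered aromatic ring with 3 hetero atoms and no hydrogen-bond donor. Nothing in the measured set tests this kind of exchange, so the expected step is not anchored by data.

The expectation is a step of a 1.5-fold lower number from compound 3 to compound 4 (0.17 log units; within the scatter), toward a somewhat shorter half-life, of a size that may or may not clear the scatter. Compound 4 is estimated at 3 h, with a range from 1.2 h to 7 h.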

Compound 4, half-life: 0.7 h
The estimate for compound 4 lay 4.3-fold (0.63 log units) above the measured number, outside the stated range (below it).
By their numbers in this assay, from the lowest: compounds 4 and 1 (each within the scatter of the next); then compounds 2 and 3 (each within the scatter of the next).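

In this assay, within the data shown here, 1,2,4-oxadiazol-3-yl in place of 1-hydroxyethyl on the aromatic carbon between two ring nitrogen atoms gives a 6.3-fold lower number from compound 3 to compound 4 (0.80 log units; beyond the scatter) as the first single-place step. With the group of 8 heavy atoms two ring bonds away left unchanged, this pair ties a change in half-life to this one position, and the step is not lost in the scatter. Nothing on hand bears on the reason for this drop.

The exchange removes a hydroxyl-bearing chain and brings in a five-membered aromatic ring with 3 hetero atoms in a single move, so the compounds shown do not separate the loss of the one from the arrival of the other. Also open, from the compounds shown here alone, is how an aminomethyl group, a carboxylic acid or a different five-membered aromatic ring on this same carbon would stand in this assay against the 1-hydroxyethyl and 1,2,4-oxadiazol-3-yl groups.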